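The source may hold more compounds than are shown below. What is called first, only, known or untested is meant among the compounds shown, and "the series" means these compounds.

Of the compounds shown here, three built on one shared core have been tested in a functional assay on HeLa cells (Homo sapiens) for inhibition, read by MTT assay, with a stated time of 48 h; on this read-out higher numbers stand for weaker inhibition and lower numbers for stronger inhibition. Compound 1 `COc1ccc2c(=O)c(/C=C/C(=O)Nc3cccc(C)c3)coc2c1` carries a 3-methylphenyl group on its amide nitrogen; in this assay compound 1 reaches only the limit of > 100000 nM. Compound 2 `COc1ccc2c(=O)c(/C=C/C(=O)NCc3ccccc3F)coc2c1`, with a 2-fluorobenzyl group in that place, likewise gives only the limit of > 100000 nM. Going by the values given here, compound 3 `COc1ccc(NC(=O)/C=C/c2coc3cc(OC)ccc3c2=O)cc1`, which bears a 4-methoxyphenyl group on the amide nitrogen, is the single compound that returns an actual number: in this assay compound 3 gives 13000 nM. As far as these compounds go, the changes an at least 7.6-fold lower number from compound 1 to compound 3 (0.88 log units; beyond the scatter) and an at least 7.6-fold lower number from compound 2 to compound 3 (0.88 log units; beyond the scatter) are both beyond the scatter, yet their true size stays open because two of the three values sit at the limit of > 100000 nM in this assay, at which 2 of the 3 values shown sit.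

Compound 4 `COc1ccc2c(=O)c(/C=C/C(=O)Nc3ccc(F)cc3)coc2c1` differs from compound 3 in one spot: fluoro in place of methoxy on an aromatic carbon. Among the measured compounds, only compound 3 has the 4-methoxyphenyl group, and only compound 3 gives a number, while compound 1 and compound 2, which lack it, stop at the limit. Among the compounds with values here, no measured step shows what a fluoro in that spot does. The step expected in this assay is therefore a 2.7-fold higher number from compound 3 to compound 4 (0.43 log units; beyond the scatter), leaning toward weaker inhibition, with a real chance that only a limit is reported. The expected value for compound 4 is 35000 nM, within a range from 8000 nM to 150000 nM.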

Compound 4, half-maximal inhibitory concentration: 9680 nM
Beside the measured number, compound 4's estimate is 3.6-fold (0.56 log units) above it, within the range that was stated.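

In this assay, going from the 4-methoxyphenyl group to the 4-fluorophenyl group gives a 1.3-fold lower number from compound 3 to compound 4 (0.13 log units; within the scatter), so compound 3 and compound 4 cannot be told apart, and this spot accepts either a methoxy or a fluoro group with no readable change. A measurable number is therefore no longer tied to the methoxy group alone, and the 4-fluorophenyl group now stands clearly apart from the other two amide groups, with an at least 10-fold lower number from compound 2 to compound 4 (1.01 log units; beyond the scatter) and an at least 10-fold lower number from compound 1 to compound 4 (1.01 log units; beyond the scatter). As far as these compounds go, the values of compound 1 and compound 2 are limits and not numbers, so the true size of these two steps stays open because neither compound has an actual value: the limit of > 100000 nM in this assay, at which 2 of the 4 values shown sit.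

From the compounds shown here alone, whether compound 3 and compound 4 owe their numbers to having any group at this spot remains open, and a plain phenyl group with nothing at that spot would be needed to settle it, while an amine or a carboxylic acid there would test how far the tolerance reaches. Going by these compounds, it is also open whether the 3-methylphenyl group of compound 1 falls short through the methyl group itself or through where it sits, which a 4-methylphenyl group could separate.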